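The source may hold more compounds than are shown below. What is called first, only, known or untested is meant among the compounds shown, and "the series" means these compounds.

In a functional assay on ECa-109 cells for inhibition, with ECa-109 cell line (Homo sapiens) as the target, read by sulforhodamine B assay (on this read-out lower numbers stand for stronger inhibition and higher numbers for weaker inhibition), the measured compounds are:
Compound 1 `Cc1ccc(NC2=CC(=O)c3nc4n(c3C2=O)[C@H]2OC[C@@H](O)[C@H]2OC4)cc1`: 3480 nM
Compound 2 `COc1ccc(NC2=CC(=O)c3c(nc4n3[C@H]3OC[C@@H](O)[C@H]3OC4)C2=O)cc1`: 3410 nM
Compound 3 `CCOc1ccc(NC2=CC(=O)c3c(nc4n3[C@H]3OC[C@@H](O)[C@H]3OC4)C2=O)cc1`: a limit of the assay, > 4000 nM

Among the two plain numbers, compound 1 has the higher one, but the gap to compound 2 lies within the scatter, so the two cannot be told apart. The third value is only a limit of the assay (the limit of > 4000 nM in this assay, at which 1 of the 3 values shown sits), so it gives no number to compare.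

Compound 4 `COc1cccc(NC2=CC(=O)c3nc4n(c3C2=O)[C@H]2OC[C@@H](O)[C@H]2OC4)c1` has not yet been measured. It differs from compound 1 at the amine nitrogen: 3-methoxyphenyl in place of 4-methylphenyl on an amine nitrogen. Among the measured compounds shown here, the only measured step, an at least 1.1-fold higher number from compound 2 to compound 3 (0.06 log units; that floor lies within the scatter), concerns the saturated chain carbon bound to oxygen on the aromatic ring and not an exchange of one aromatic substituent for another, so no measured step speaks directly to this change. What the numbers do show is that the methyl-bearing ring of compound 1 and the methoxy-bearing ring of compound 2 sit within the scatter of each other. The expectation is therefore a step of a 1.0-fold higher number from compound 1 to compound 4 (0.00 log units; within the scatter), which is none beyond the scatter. Compound 4 is estimated at 3500 nM, with a range from 1500 nM to 8000 nM.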

Compound 4, half-maximal inhibitory concentration: 7620 nM
For compound 4 the middle estimate is 2.2-fold (0.34 log units) below the measured one; the measured number falls inside the stated range.
By their numbers in this assay, from the lowest: compounds 2 and 1 (each within the scatter of the next); then compound 4.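

In this assay, among the compounds shown here, the change from 4-methylphenyl to 3-methoxyphenyl on the amine nitrogen gives a 2.2-fold higher number from compound 1 to compound 4 (0.34 log units; beyond the scatter), the first step at this position that clearly exceeds the scatter. Compound 1 and compound 2 had stayed within the scatter of each other, so the aromatic ring on this nitrogen had seemed tolerant of change, but the result shows that the read-out can respond to what the ring carries, though only modestly here. Compound 2 also carries a methoxy group on its ring and gives 3410 nM, while compound 4 gives 7620 nM, so the presence of a methoxy group does not by itself set the number. Compound 3 adds no number to this comparison because its value is a limit: the limit of > 4000 nM in this assay, at which 1 of the 4 values shown sits.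

Why the 3-methoxyphenyl ring gives the higher number stays open, since these few compounds give no measurement that explains it. Going by these compounds, it is also open how the number would move with a chlorine, an amine or a carboxylic acid on the ring, or with a cyclohexyl group in place of the aromatic ring.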